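This account rests on a few compounds, and the source may have more. Where it says the series, first, only, none or still open, it means among the compounds named here.

Of the compounds shown here, three sharing one core have been measured in an assay on CHO cells for displacement of a labelled ligand from adenosine receptor A1 (Homo sapiens), read by scintillation counting, tested at 1 uM; a higher number here means more inhibition at the concentration tested (going by the name of the read-out), a lower number less inhibition. Compound 1 `CC(C)Cc1nc(N)c2nn(-c3ccccc3)cc2n1` gives 49%. Compound 2 `Cc1cccc(Cc2nc(N)c3nn(-c4ccccc4)cc3n2)c1` gives 41%, and compound 3 `Nc1nc(Cc2cccc(Cl)c2)nc2cn(-c3ccccc3)nc12` gives 32%. Compound 3 thus carries the lowest of the three numbers, but only its gap to compound 1 is clear: the step of a number 17 percentage points lower from compound 1 to compound 3 (beyond the scatter) lies beyond the scatter, whereas the step of a number 9 percentage points lower from compound 2 to compound 3 (within the scatter) lies within it, so compound 2 and compound 3 cannot be told apart on these numbers. The step of a number 8 percentage points lower from compound 1 to compound 2 (within the scatter) is likewise within the scatter.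

Compound 4 `Nc1nc(Cc2ccc(O)cc2)nc2cn(-c3ccccc3)nc12` has not yet been measured. It differs from compound 3 in one place: 4-hydroxyphenyl in place of 3-chlorophenyl on a saturated chain carbon bound to an aromatic carbon. Among the measured compounds shown here, the measured step that bears most directly on this change is the one from compound 2 to compound 3, where one group on the same aromatic ring was exchanged for another and the number moved only within the scatter. For the measured compounds named here, no measured step involves a hydroxyl group or a change of where the group sits on that ring, so nothing in the data points to a larger movement. A step of a number 3 percentage points higher from compound 3 to compound 4 (within the scatter) is therefore expected, meaning no change beyond the scatter. Compound 4 is estimated to give 35% in this assay, with a range from 20% to 50%.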

Compound 4, a percentage reported as inhibition, at one concentration (the size of the read-out at that concentration, not a potency): 39%
The estimate for compound 4 lay 4 percentage points below the measured number; measured number inside the range.
By their numbers in this assay, from the lowest: compounds 3, 4, 2 and 1 (each within the scatter of the next, the first and the last beyond it).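

In this assay, putting 4-hydroxyphenyl in place of 3-chlorophenyl on the saturated chain carbon gives a number 7 percentage points higher from compound 3 to compound 4 (within the scatter), so a group counted as one hydrogen-bond donor and one hydrogen-bond acceptor enters here without a change that can be told from the scatter. The comparisons with the other two compounds add to this: replacing 3-methylphenyl gives a number 2 percentage points lower from compound 2 to compound 4 (within the scatter), and replacing isopropyl gives a number 10 percentage points lower from compound 1 to compound 4 (within the scatter), whereas the step from isopropyl to 3-chlorophenyl gives a number 17 percentage points lower from compound 1 to compound 3 (beyond the scatter), so among the three aromatic-ring and isopropyl exchanges from compound 1, only the 3-chlorophenyl one stands clear of the scatter. No measurement shown here offers an explanation for these numbers.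

In the step to compound 4, the group on the ring and its place on the ring change together, so the contribution of each cannot be separated. As far as these compounds go, it also remains open whether an amine or a carboxylic acid on that aromatic ring, or a longer chain in place of isopropyl, would move the number in this assay beyond the scatter.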